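Enlarging the aromatic-nitrogen group of compound 2

The compounds below may be only part of what the source reports. "The series", "measured", "known", "first", "only" and "open" are said of these compounds alone.

In a functional assay on LNCaP cells (Homo sapiens) for cytotoxicity (a higher number here means a weaker inhibitor, a lower number a stronger inhibitor), compound 2 `CNC(=O)Nc1ccc(-c2nc(N3CC4CCC(C3)O4)c3cnn(CCO)c3n2)cc1` gives 650 nM, the highest of three numbers, against compound 1 `O=C(Nc1ccccc1)Nc1ccc(-c2nc(N3CC4CCC(C3)O4)c3cnn(C4CCC5(CC4)OCCO5)c3n2)cc1` at 4 nM and compound 3 `O=C(Nc1ccc(-c2nc(N3CC4CCC(C3)O4)c3cnn(C4CCC5(CC4)OCCO5)c3n2)cc1)NC1CC1` at 2 nM. Compound 4 `CNC(=O)Nc1ccc(-c2nc(N3CC4CCC(C3)O4)c3cnn(C4CCC(OC)(OC)CC4)c3n2)cc1` departs from compound 2 through (a group of 10 heavy atoms (8 carbon, 2 oxygen; one six-membered non-aromatic ring of carbon only) in place of a group of 3 heavy atoms (2 carbon, 1 oxygen; no ring), on an aromatic nitrogen). For the measured compounds named here, compounds 1 and 3 also carry a six-membered non-aromatic ring of carbon only on that nitrogen, but they differ from compound 2 elsewhere too, so no measured step isolates this change. Going by the values given here, the only measured step, cyclopropyl in place of phenyl on an amide-type nitrogen, is a 2.0-fold lower number from compound 1 to compound 3 (0.30 log units; within the scatter), within the scatter. The expected step is a 54-fold lower number from compound 2 to compound 4 (1.73 log units; beyond the scatter), towards a lower number and beyond the scatter. For compound 4 the estimate is 12 nM, with an expected range of 3 nM to 60 nM.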

Compound 4, half-maximal inhibitory concentration: 2 nM
For compound 4 the middle estimate is 6.0-fold (0.78 log units) above the measured one, outside the stated range (below it).
By their numbers in this assay, from the lowest: compounds 3, 4 and 1 (each within the scatter of the next); then compound 2.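

In this assay, for the compounds shown here, a group of 10 heavy atoms with a six-membered non-aromatic carbon ring in place of 2-hydroxyethyl on the aromatic nitrogen gives a 330-fold lower number from compound 2 to compound 4 (2.51 log units; beyond the scatter) and this is the first measured step to isolate that position. The substituent on this nitrogen alone can therefore shift the cytotoxicity number strongly in this series. Nothing available explains the size of this step.

The compounds shown leave open whether the gain requires the ring or the two methoxy groups. An unsubstituted cyclohexyl group or a piperidine on that nitrogen would separate these contributions.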